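This account rests on a few compounds, and the source may have more. Where it says the series, first, only, none or still open, it means among the compounds named here.

Measured so far:
compound 1 `O=C(NCc1ccc(S(=O)(=O)c2ccccc2)cc1)c1cc2ccncc2s1` — 7 nM
compound 2 `O=C(NCc1ccc(S(=O)(=O)c2ccccc2C(F)(F)F)cc1)c1cc2cnccc2[nH]1` — 24 nM
compound 3 `O=C(NCc1ccc(S(=O)(=O)N2CCCCC2)cc1)c1cc2cnccc2o1` — 140 nM

All three numbers come from an assay for inhibition of Nicotinamide phosphoribosyltransferase (Homo sapiens), read by mass spectrometry, with stated times of 15 min and 30 min; a higher number here means a weaker inhibitor, a lower number a stronger inhibitor. Compound 1 stands lowest of the three; compound 2 and compound 3 each sit beyond the scatter above it, compound 3 farthest. For the measured compounds named here, no pair here differs in one place only, so no single-change step is known.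

Compound 4 `O=C(NCc1ccc(S(=O)(=O)c2ccccc2)cc1)c1ccc2nncn2c1` differs from compound 1 by a group of 9 heavy atoms (6 carbon, 3 nitrogen; one five-membered aromatic ring with 3 hetero atoms, one six-membered aromatic ring with 1 hetero atom) in place of a group of 9 heavy atoms (7 carbon, 1 nitrogen, 1 sulfur; one five-membered aromatic ring with 1 hetero atom, one six-membered aromatic ring with 1 hetero atom), on a carbonyl carbon. The shared core and the sulfone-bearing side are kept. Going by the values given here, with no comparable step among the measured compounds, the direction of this change is open; a modest rise in the number, possibly beyond the scatter, is expected, a 4.3-fold higher number from compound 1 to compound 4 (0.63 log units; beyond the scatter). Compound 4 is estimated at 30 nM, within 8 nM to 150 nM.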

Compound 4, half-maximal inhibitory concentration: 370 nM
Estimate against measurement, compound 4: 12-fold (1.09 log units) below; measured number outside the range, above it.
By their numbers in this assay, from the lowest: compound 1; then compound 2; then compound 3; then compound 4.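

On the carbonyl carbon, groups of equal heavy-atom count are not interchangeable: in this assay, replacing the group with one hetero atom in its five-membered aromatic ring by the group with 3 gives a 53-fold higher number from compound 1 to compound 4 (1.72 log units; beyond the scatter), a large step with the sulfone-bearing side kept. Matching ring sizes and the absence of hydrogen-bond donors in both groups therefore do not preserve the low number of compound 1. No measurement shown bears on the reason for this step.

Open, going by these compounds, is whether the sulfur or the added nitrogens account for the step, and whether an amine on the entering group would bring the number back down.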